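The source may hold more compounds than are shown below. What is called first, only, known or untested is meant among the compounds shown, and "the series" means these compounds.

Compound 1 `Cc1ccc(-c2cc(C(=O)N3CCC4(CC3)CC(=O)c3nn(C(C)(C)C)cc3O4)c3ccccc3n2)cc1` — 1440 nM
Compound 2 `CC(C)(C)n1cc2c(n1)C(=O)CC1(CCN(C(=O)c3cc(-c4ccc(Cl)cc4)nc4ccccc34)CC1)O2` — 630 nM
Compound 3 `CC(C)(C)n1cc2c(n1)C(=O)CC1(CCN(C(=O)c3cc(-c4ccccc4Cl)nc4ccccc34)CC1)O2` — > 10000 nM

In a functional assay on HepG2 cells (Homo sapiens) for inhibition, read by MTT assay, with a stated time of 72 h (on this read-out higher numbers stand for weaker inhibition and lower numbers for stronger inhibition), compound 2 gives 630 nM, the lowest of the two numbers shown; its nearest neighbour is compound 1, with a 2.3-fold lower number from compound 1 to compound 2 (0.36 log units; beyond the scatter). Compound 3 reaches only the limit of the assay, > 10000 nM, and reports no number (the limit of > 10000 nM in this assay, at which 1 of the 3 values shown sits). Compound 4 `CC(C)(C)n1cc2c(n1)C(=O)CC1(CCN(C(=O)c3cc(N4CCNCC4)nc4ccccc34)CC1)O2` differs from compound 2 by a single change: piperazin-1-yl in place of 4-chlorophenyl on an aromatic carbon. Among the compounds with values here, no measured step swaps the 4-chlorophenyl group for a non-aromatic ring; the closest evidence comes from changes within that group. The step of a 2.3-fold lower number from compound 1 to compound 2 (0.36 log units; beyond the scatter) was modest, while an at least 15-fold higher number from compound 2 to compound 3 (1.20 log units; beyond the scatter) was large. The identity of the 4-chlorophenyl group therefore matters strongly in this assay, and replacing it by piperazin-1-yl is a larger departure than either measured step. Compound 4 is thus expected to give a higher number, a 5.6-fold higher number from compound 2 to compound 4 (0.74 log units; beyond the scatter), with a real chance that only a limit is returned. The estimate for compound 4 is 3500 nM, ranging from 900 nM to 15000 nM.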

Compound 4, half-maximal inhibitory concentration: 8570 nM
For compound 4 the middle estimate is 2.4-fold (0.39 log units) below the measured one; the measured number falls inside the stated range.
By their numbers in this assay, from the lowest: compound 2; then compound 1; then compound 4. At a limit, above all of these: compound 3.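

In this assay compound 4 is the first of the compounds shown to carry a non-aromatic ring on the aromatic carbon next to the ring nitrogen, and it still gives a measured number. That ring costs a large step against the 4-chlorophenyl group (a 14-fold higher number from compound 2 to compound 4 (1.13 log units; beyond the scatter)) and a modest one against the 4-methylphenyl group (a 6.0-fold higher number from compound 1 to compound 4 (0.77 log units; beyond the scatter)), so both of these aromatic rings give lower numbers here than piperazin-1-yl does. The step from the 2-chlorophenyl group (an at least 1.1-fold lower number from compound 3 to compound 4 (0.06 log units; that floor lies within the scatter)) has a floor that lies within the scatter, so it sets no order. Compound 3 stays a limit: the limit of > 10000 nM in this assay, at which 1 of the 4 values shown sits.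

The compounds shown leave open whether the higher number goes with losing the aromatic ring or with the nitrogens of the piperazine. Going by these compounds, what a piperidine or a morpholine ring would give on this carbon remains unknown, as does the effect of a methyl group on the free piperazine nitrogen.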